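The source may hold more compounds than are shown below. What is called first, only, known or untested is meant among the compounds shown, and "the series" means these compounds.

Measured compounds:
compound 1 `Cc1cccc(-c2noc([C@H](C)NC(=O)c3cc(C4CC4)n(C)n3)n2)c1` — > 30000 nM in an assay on T-REx-293 cells for inhibition of potassium channel subfamily T member 1 (Homo sapiens), read by patch clamp; a higher number here means a weaker inhibitor, a lower number a stronger inhibitor
compound 2 `Cc1cccc(-c2nc(C(C)NC(=O)c3cc(C(F)(F)F)nn3C)no2)c1` — 977 nM in this assay
compound 3 `Cc1cccc(-c2noc([C@H](C)NC(=O)c3cc(C(F)(F)F)nn3C)n2)n1` — > 30000 nM in this assay

The value for compound 1 is a limit of the assay, not a number. The value for compound 3 is likewise a limit, not a number. Compound 2 alone gives a measured figure, and it sits well inside the measurable range. For the measured compounds named here, for compound 3, then, only the upper side of the range is fixed: two of the three values shown rest at the same limit (the limit of > 30000 nM in this assay, at which 2 of the 3 values shown sit), and no step between measured compounds is available that would tie the aryl group on the shared core to the read-out.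

The unmeasured compound 4 `C[C@H](NC(=O)c1cc(C(F)(F)F)nn1C)c1nc(-c2cccnc2)no1` differs from compound 3 in one place: pyridin-3-yl in place of 6-methylpyridin-2-yl on an aromatic carbon. The methyl group is lost and the ring nitrogen moves with the change of attachment. Whether this lifts compound 4 off the limit is not settled by the data shown; compound 2, with its 3-methylphenyl group, shows that an aryl ring of this kind can carry measurable inhibition, while compound 3 shows that a methylated pyridin-2-yl does not.

Compound 4 is therefore expected at roughly 12000 nM, within 2000 nM to 40000 nM, with a fair chance that only a limit is returned; the expected step of an at least 2.5-fold lower number from compound 3 to compound 4 (0.39 log units; beyond the scatter) is an estimate, not a measured difference.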

Compound 4, half-maximal inhibitory concentration: 11800 nM
Beside the measured number, compound 4's estimate is 1.0-fold (0.01 log units) above it; the measured number falls inside the stated range.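

For the compounds shown here, on the aromatic carbon between two ring nitrogen atoms of the shared core, pyridin-3-yl in place of 6-methylpyridin-2-yl gives the only readable step so far: an at least 2.5-fold lower number from compound 3 to compound 4 (0.40 log units; beyond the scatter) in this assay. In this assay compound 4 gives 11800 nM, so a pyridine ring at this position can carry measurable inhibition, which compound 3 alone could not show. Compound 3 rests at a limit of the assay, not a number, and the full size of the step therefore stays open on one side: the limit of > 30000 nM in this assay, at which 2 of the 4 values shown sit.

The change removes the methyl group and alters the attachment of the pyridine ring in a single move, and the compounds shown do not separate these two parts. Unsubstituted pyridin-2-yl and 6-methylpyridin-3-yl on the same carbon would separate them, and pyridin-4-yl would extend the comparison to a further placement of the ring nitrogen.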